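Chloro in place of methoxy on compound 2

The source may report more compounds than this note shows. Statements on the series, on what has been measured and on what is new or still open speak of the compounds shown alone.

Among the compounds with values here, in a functional assay on DU-145 cells (Homo sapiens) for cytotoxicity, read by trypan blue exclusion, with a stated time of 96 h (a lower number here means a stronger inhibitor, a higher number a weaker inhibitor), compound 1 (`COc1ccc(/C=C/S(=O)(=O)Cc2ccc(OC)c(N)c2)c(OC)c1`) gives 500 nM and compound 2 (`COc1cc(OC)c(/C=C/S(=O)(=O)Cc2ccc(OC)c(N)c2)c(OC)c1`) gives 4 nM as the lower of the two numbers so far. Compound 3 (`COc1cc(OC)c(/C=C/S(=O)(=O)Cc2ccc(Cl)c(N)c2)c(OC)c1`) carries chloro in place of methoxy on an aromatic carbon, ortho to an amino group and para to a large group (chloro in place of methoxy on an aromatic carbon). The group changes from 3-amino-4-methoxyphenyl to 3-amino-4-chlorophenyl. Within the data shown here, the only measured step (a 130-fold lower number from compound 1 to compound 2 (2.10 log units; beyond the scatter)) is a large one, but it is methoxy in place of hydrogen at a different place on the shared core. It therefore sets no size here and shows only that one aromatic substituent can move the number widely. No measurement covers the present position. For compound 3 a moderately higher number, beyond the scatter, is expected (a 7.5-fold higher number from compound 2 to compound 3 (0.88 log units; beyond the scatter)). Compound 3 is estimated at 30 nM with a wide expected range (6 nM to 200 nM).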

Compound 3, half-maximal inhibitory concentration: 10 nM
Compound 3: middle estimate off by 3.0-fold (0.48 log units), on the high side; measured number inside the range.
By their numbers in this assay, from the lowest: compound 2; then compound 3; then compound 1.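

In this assay the change from 3-amino-4-methoxyphenyl to 3-amino-4-chlorophenyl costs little: the step is a 2.5-fold higher number from compound 2 to compound 3 (0.40 log units; beyond the scatter) and counts as modest, though it lies beyond the scatter. Compound 3 still gives 10 nM, so on this core the methoxy at this place, ortho to an amino group, can give way to chloro, a single heavy atom with no hydrogen-bond acceptor, and the number stays low. Within the data shown here, this is the first reading at this position, as the earlier step concerned another place on the shared core, and no measured data here explain the shift.

Still open, on these data alone, is whether other groups at this position, such as fluoro, methyl or ethoxy, would stay close to compound 2 or compound 3. Also open, as far as these compounds go, is whether chloro would read the same with an acetamide in place of the amino group.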